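A few compounds are considered here, and "the series" means these few. Any claim that something is new, unique, unknown or untested is made for them only; others in the source may bear on it.

Compound 1 `O=C(NC(=S)Nc1ccc(Cl)c(-c2nc3ccccc3[nH]2)c1)c1ccc(OCc2ccc(Cl)c(Cl)c2)cc1` and compound 2 `Cc1ccc(NC(=O)NC(=O)c2ccc(OCc3cccc(Cl)c3Cl)cc2)cc1-c1nc2ccccc2[nH]1` share a core but differ in their linker and in the substituents around it. In a functional assay on MGC-803 cells (Homo sapiens) for inhibition, read by MTT assay, with a stated time of 48 h (a lower number here means a stronger inhibitor, a higher number a weaker inhibitor), compound 1 gives 5170 nM. Compound 2, in this assay, is known only as a limit, > 100000 nM; it sits at the limit of > 100000 nM in this assay, at which 1 of the 2 values shown sits. Compound 3 `Cc1ccc(NC(=O)NC(=O)c2ccc(OCc3ccc(F)cc3)cc2)cc1-c1nc2ccccc2[nH]1` is compound 2 with 4-fluorophenyl in place of 2,3-dichlorophenyl on a saturated chain carbon bound to an oxygen on an aromatic ring. For the measured compounds named here, no measured step touches this change, so the expected step from compound 2 to compound 3 is a number no higher from compound 2 to compound 3 (the limit leaves the size open), uncertain in direction and probably within the scatter. Compound 3 is therefore estimated at 100000 nM, with a range from 20000 nM to 400000 nM.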

Compound 3, half-maximal inhibitory concentration: 160 nM
Compound 3: the middle estimate sits 630-fold (2.80 log units) above what was measured; measured number outside the range, below it.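

In this assay, 4-fluorophenyl in place of 2,3-dichlorophenyl on a saturated chain carbon bound to an oxygen on an aromatic ring gives an at least 620-fold lower number from compound 2 to compound 3 (2.79 log units; beyond the scatter). This is the first pair shown that differs in one place, and it shows that this group alone can decide the read-out when the rest of the molecule stays fixed. Compound 2 stands only as a limit, so the true size of the step stays open on one side: the limit of > 100000 nM in this assay, at which 1 of the 3 values shown sits.

As far as these compounds go, how 4-chlorophenyl or plain phenyl would stand at this place remains open. So does whether 4-fluorophenyl would give a similar step on the linker of compound 1.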